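Adding a chloro group to the benzyl ring

This account rests on a few compounds, and the source may have more. Where it says the series, first, only, none or still open, it means among the compounds named here.

Measured in a functional assay on A549 cells (Homo sapiens) for cytotoxicity, read by MTT assay, with a stated time of 72 h; a higher number here means a weaker inhibitor, a lower number a stronger inhibitor:
compound 1 `CN(C)Cc1ccc2nc(NC(=O)N/N=C/c3c[nH]c4ccccc34)sc2c1`: 3300 nM
compound 2 `CCN(CC)Cc1ccc2nc(NC(=O)N/N=C/c3cn(Cc4ccc(Cl)cc4)c4ccccc34)sc2c1`: 2940 nM
compound 3 `CN(C)Cc1ccc2nc(NC(=O)N/N=C/c3cn(Cc4ccccc4)c4ccccc34)sc2c1`: 2900 nM

The three values lie within the usual scatter of one another, so compound 3 cannot be ranked against the other two. Compound 4 `CN(C)Cc1ccc2nc(NC(=O)N/N=C/c3cn(Cc4ccc(Cl)cc4)c4ccccc34)sc2c1` differs from compound 3 in one place: chloro in place of hydrogen on an aromatic carbon. This turns benzyl into 4-chlorobenzyl. For the measured compounds named here, no measured step makes exactly this change. The closest one, a 1.1-fold lower number from compound 1 to compound 3 (0.06 log units; within the scatter), brought in the benzyl itself and stayed within the scatter. Compound 2 also carries 4-chlorobenzyl, with a different amine, and gives 2940 nM. The expected result is therefore no step beyond the scatter in this assay, in either direction: a 1.0-fold lower number from compound 3 to compound 4 (0.02 log units; within the scatter) is the estimated step. For compound 4 the estimated value is 2800 nM, with a range of 1300 nM to 5500 nM.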

Compound 4, half-maximal inhibitory concentration: 840 nM
Estimate against measurement, compound 4: 3.3-fold (0.52 log units) above; the whole stated range lies above it.
By their numbers in this assay, from the lowest: compound 4; then compounds 3, 2 and 1 (each within the scatter of the next).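

In this assay the chloro group on the benzyl ring gives a real gain (a 3.5-fold lower number from compound 3 to compound 4 (0.54 log units; beyond the scatter)), although benzyl alone stayed within the scatter (a 1.1-fold lower number from compound 1 to compound 3 (0.06 log units; within the scatter)). The full 4-chlorobenzyl in place of hydrogen on the aromatic nitrogen also gives a gain beyond the scatter (a 3.9-fold lower number from compound 1 to compound 4 (0.59 log units; beyond the scatter)). The amine matters as well, since dimethylamino in place of diethylamino gives a gain of similar size (a 3.5-fold lower number from compound 2 to compound 4 (0.54 log units; beyond the scatter)). Going by these compounds, whether fluoro, bromo or methoxy on that ring would do the same remains open, as does chloro elsewhere on the ring. No evidence available here accounts for these gains.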